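The source may report more compounds than this note shows. Statements on the series, on what has been measured and on what is new or still open speak of the compounds shown alone.

Of the compounds shown here, three sharing one core have been measured in a functional assay on MCF7 cells (Homo sapiens) for inhibition, read by MTT assay, with a stated time of 48 h, tested at 10 uM; a lower number here means less inhibition of growth, a higher number more inhibition of growth at the concentration tested. Compound 1 `Cc1oc2c([C@H]3CCN(C)C[C@H]3O)c(O)cc(O)c2c(=O)c1C(O)c1c(Cl)cccc1Cl` gives 33%, compound 2 `Cc1oc2c([C@H]3CCN(C)C[C@H]3O)c(O)cc(O)c2c(=O)c1C(O)c1csc([N+](=O)[O-])c1` gives 20%, and compound 3 `CCOc1ccc(Br)c(C(O)c2c(C)oc3c([C@H]4CCN(C)C[C@H]4O)c(O)cc(O)c3c2=O)c1` gives 9%, the lowest of the three. Compound 4 `Cc1oc2c([C@H]3CCN(C)C[C@H]3O)c(O)cc(O)c2c(=O)c1C(O)c1cccc(Cl)c1Cl` differs from compound 3 in one group: 2,3-dichlorophenyl in place of 2-bromo-5-ethoxyphenyl on a saturated chain carbon bound to an aromatic carbon and an oxygen on a saturated carbon, with 2,3-dichlorophenyl in place of 2-bromo-5-ethoxyphenyl on a saturated chain carbon bound to an aromatic carbon and an oxygen on a saturated carbon. Compound 1 also carries a dichlorophenyl group, so the step that bears most on this change is a number 24 percentage points lower from compound 1 to compound 3 (beyond the scatter). The step of a number 11 percentage points lower from compound 2 to compound 3 (beyond the scatter) starts from a different kind of group and bears less. The two dichlorophenyl groups are not identical, so only part of the first step is expected to return, as a modest rise in this assay. The expected change is a number 18 percentage points higher from compound 3 to compound 4 (beyond the scatter). For compound 4 the estimated value is 27%, with an expected range of 12% to 42%.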

Compound 4, percent growth inhibition at one concentration: 7%
For compound 4 the middle estimate is 20 percentage points above the measured one; measured number outside the range, below it.
By their numbers in this assay, from the lowest: compounds 4 and 3 (each within the scatter of the next); then compound 2; then compound 1.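

Replacing 2,6-dichlorophenyl with 2,3-dichlorophenyl gives a number 26 percentage points lower from compound 1 to compound 4 (beyond the scatter) in this assay, so at this position, carrying two chlorines does not by itself keep the higher number; the pattern named in each group matters. Replacing 2-bromo-5-ethoxyphenyl with 2,3-dichlorophenyl gives a number 2 percentage points lower from compound 3 to compound 4 (within the scatter), and replacing 5-nitrothiophen-3-yl with it gives a number 13 percentage points lower from compound 2 to compound 4 (beyond the scatter). Nothing available explains why these groups differ. The compounds shown leave open how a phenyl ring with a single chlorine would behave on this carbon, or one carrying an amine or a carboxylic acid.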